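The source may hold more compounds than are shown below. What is called first, only, known or untested is meant among the compounds shown, and "the series" means these compounds.

Compound 1 `Nc1ccccc1NC(=O)/C=C/c1ccc(CSc2ccc(Cl)cc2)cc1`: 1.94%
Compound 2 `Nc1ccccc1NC(=O)c1ccc(CSc2nccc(C(F)(F)F)n2)cc1`: 68.3%
Compound 3 `COc1ccc(SCc2ccc(C(=O)Nc3ccccc3N)cc2)cc1OC`: 15.2%

All three values come from a functional assay on HeLa cells (Homo sapiens) for inhibition, read by CCK-8 assay, with a stated time of 72 h, tested at 2 uM; on this read-out lower numbers stand for less inhibition of growth and higher numbers for more inhibition of growth at the one concentration tested. Compound 1 stands lowest of the three at 1.94%, so it shows almost no inhibition of growth at the concentration tested. Compound 3 is the nearest, and its value lies higher by more than the scatter. Compound 2 is the furthest, at 68.3%, far beyond the scatter.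

The next compound to be tested is compound 4 `CC(C)(C)c1ccc(SCc2ccc(/C=C/C(=O)Nc3ccccc3N)cc2)cc1`, which keeps the core of compound 1 and changes one substituent: tert-butyl in place of chloro on an aromatic carbon. This is tert-butyl in place of chloro, on an aromatic carbon, para to a large group.

Among the compounds with values here, compound 2 and compound 3 each differ from compound 1 in more than one place, so no measured pair shows what this single change does. The expectation therefore starts from compound 1 at 1.94%, and a small upward move or none beyond the scatter seems most likely. The expected change is a number 6.1 percentage points higher from compound 1 to compound 4 (within the scatter), an estimate that stays within the scatter, although a larger rise cannot be excluded. For compound 4 the estimated value is 8%, with an expected range of 0% to 30%.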

Compound 4, percent growth inhibition at one concentration: 17.5%
Compound 4: the middle estimate sits 9.5 percentage points below what was measured; the measured number falls inside the stated range.
By their numbers in this assay, from the lowest: compound 1; then compounds 3 and 4 (each within the scatter of the next); then compound 2.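

In this assay, within the data shown here, tert-butyl in place of chloro, on an aromatic carbon para to a large group, gives a number 15.6 percentage points higher from compound 1 to compound 4 (beyond the scatter), and this is the first comparison here in which only one place differs. With the rest of the core of compound 1 held fixed, it shows that this position is not indifferent to the group it carries: exchanging a single chlorine atom for the four carbon atoms of tert-butyl produces a modest but readable rise in growth inhibition at the one concentration tested. Nothing measured here bears on the reason for this rise.

Going by these compounds, what an amine, a carboxylic acid or a smaller carbon group such as methyl would do at this same position remains open, so a single step cannot show whether the number follows the size of the group or something else about tert-butyl. On these data alone, it also remains open whether tert-butyl in place of chloro would give a similar move on any core other than that of compound 1.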